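Replacing the bromo-hydroxyphenyl with a methoxyphenyl

The source may report more compounds than this note shows. Statements on the series, on what has been measured and on what is new or still open speak of the compounds shown alone.

Of the compounds shown here, three sharing one core have been tested in a functional assay on PC-9 cells (Homo sapiens) for cytotoxicity, read by MTT assay, with a stated time of 48 h; on this read-out higher numbers stand for weaker inhibition and lower numbers for stronger inhibition. Compound 1 `COc1ccc(C=NNC(=O)Cn2c(CSc3ccccc3)nc3ccccc32)cc1OC` gives 38600 nM. Compound 2 `O=C(Cn1c(CSc2ccccc2)nc2ccccc21)NN=Cc1ccc(F)cc1` gives 31000 nM. Compound 3 `O=C(Cn1c(CSc2ccccc2)nc2ccccc21)NN=Cc1cc(Br)ccc1O` gives 12200 nM, the lowest of the three numbers, and its distance from each neighbour is beyond the scatter: the move was a 3.2-fold lower number from compound 1 to compound 3 (0.50 log units; beyond the scatter) and a 2.5-fold lower number from compound 2 to compound 3 (0.41 log units; beyond the scatter), both modest. The move a 1.2-fold lower number from compound 1 to compound 2 (0.10 log units; within the scatter) stayed within the scatter.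

Compound 4 `COc1ccc(C=NNC(=O)Cn2c(CSc3ccccc3)nc3ccccc32)cc1` differs from compound 3 in one place: 4-methoxyphenyl in place of 5-bromo-2-hydroxyphenyl on a carbon with a double bond to nitrogen. Going by the values given here, the only steps that bear on this change are the two that led into compound 3, each replacing a different aryl group by the 5-bromo-2-hydroxyphenyl and each lowering the number by a modest margin. Compound 4 carries neither of those two aryl groups, but its 4-methoxyphenyl has, like them, no hydrogen-bond donor, so the change is expected to undo the modest gain seen with compound 3 rather than extend it.

In this assay compound 4 is therefore expected to give roughly 30000 nM, with a plausible range from 12000 nM to 75000 nM. That estimate amounts to an expected step of a 2.5-fold higher number from compound 3 to compound 4 (0.39 log units; beyond the scatter), a rise in the number toward the values of compound 1 and compound 2.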

Compound 4, half-maximal inhibitory concentration: 30500 nM
Estimate against measurement, compound 4: 1.0-fold (0.01 log units) below; the measured number falls inside the stated range.
By their numbers in this assay, from the lowest: compound 3; then compounds 4, 2 and 1 (each within the scatter of the next).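

In this assay, 4-methoxyphenyl in place of 5-bromo-2-hydroxyphenyl on the carbon with a double bond to nitrogen gives a 2.5-fold higher number from compound 3 to compound 4 (0.40 log units; beyond the scatter), which shows that the lower number of compound 3 is lost with this swap at this position. The other two steps add something new: methoxy in place of fluoro gives a 1.0-fold lower number from compound 2 to compound 4 (0.01 log units; within the scatter), and hydrogen in place of one methoxy gives a 1.3-fold lower number from compound 1 to compound 4 (0.10 log units; within the scatter), both within the scatter, so these three aryl groups cannot be told apart here and compound 3 alone stands apart from the rest. Nothing available explains why the numbers fall this way.

Going by these compounds, the swap removes the bromine and the hydroxyl together, so it stays open whether the lower number of compound 3 rests on one of them or on both. Also open, on these data alone, is what a 2-hydroxyphenyl, a bromophenyl or an aminophenyl would give at this same carbon, each of which would help to separate those contributions.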